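The compounds below may be only part of what the source reports. "The series", "measured", "known", "first", "only" and "open" are said of these compounds alone.

In an ADME assay on MT4 cells (Homo sapiens) for cytotoxicity, read by MTT assay (on this read-out lower numbers stand for higher toxicity in this test and higher numbers for lower toxicity in this test), compound 1 `O=C1c2ccccc2C(=O)N1CCOC(=S)N(C(=O)c1ccc(F)cc1F)c1ccc(Cl)cc1`, which carries 2,4-difluorophenyl on a carbonyl carbon, gives 52000 nM. Compound 2 `O=C1c2ccccc2C(=O)N1CCOC(=S)N(C(=O)c1cc(F)cc(F)c1)c1ccc(Cl)cc1`, with 3,5-difluorophenyl there, gives 59000 nM, and a 1.1-fold higher number from compound 1 to compound 2 (0.05 log units; within the scatter) lies within the scatter. Compound 3 `O=C1c2ccccc2C(=O)N1CCOC(=S)N(C(=O)c1c(Cl)cccc1Cl)c1ccc(Cl)cc1`, with 2,6-dichlorophenyl on that carbon, gives 20000 nM, the lowest of the three numbers. It stands apart from the other two by modest steps beyond the scatter: a 2.6-fold lower number from compound 1 to compound 3 (0.41 log units; beyond the scatter) and a 3.0-fold lower number from compound 2 to compound 3 (0.47 log units; beyond the scatter).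

Compound 4 `Cc1ccc(N(C(=O)c2c(Cl)cccc2Cl)C(=S)OCCN2C(=O)c3ccccc3C2=O)cc1` keeps the 2,6-dichlorophenyl group of compound 3 and differs elsewhere: methyl in place of chloro on an aromatic carbon. This puts methyl in place of chloro on an aromatic carbon, para to a large group, turning 4-chlorophenyl into 4-methylphenyl. Among the compounds with values here, none of the measured steps touches that place, since all three change the group on the carbonyl carbon, so the data offer no direct guide to this swap. They show only how far these compounds have moved so far, and the largest move, a 3.0-fold lower number from compound 2 to compound 3 (0.47 log units; beyond the scatter), is modest. No step beyond the scatter is therefore expected in this assay, though a modest one in either direction remains possible. The step expected is a 1.3-fold higher number from compound 3 to compound 4 (0.10 log units; within the scatter). Compound 4 is expected at 25000 nM, with an estimated range from 10000 nM to 60000 nM.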

Compound 4, half-maximal cytotoxic concentration: 22000 nM
Beside the measured number, compound 4's estimate is 1.1-fold (0.06 log units) above it; measured number inside the range.
By their numbers in this assay, from the lowest: compounds 3 and 4 (each within the scatter of the next); then compounds 1 and 2 (each within the scatter of the next).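

In this assay, turning 4-chlorophenyl into 4-methylphenyl is the first change shown that leaves the group on the carbonyl carbon alone, and a 1.1-fold higher number from compound 3 to compound 4 (0.04 log units; within the scatter) keeps this step within the usual scatter. At this place on the ring, para to a large group, methyl and chloro therefore cannot be told apart by this read-out, at least with 2,6-dichlorophenyl on the carbonyl carbon, so the position tolerates this one exchange without a change that can be read. Within the data shown here, nothing given here accounts for this outcome, and the single pair supports only the observation itself.

The compounds shown leave open whether the same exchange would also stay within the scatter with 2,4-difluorophenyl or 3,5-difluorophenyl on the carbonyl carbon, since the step is seen with only one such group. They also leave open whether this position would respond to a group of a different kind, such as an amine, a carboxylic acid, methoxy or trifluoromethyl, or whether the read-out stays this flat only for the exchange of chloro and methyl.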